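Phenyl in Place of Hydrogen on Compound 1

The source may report more compounds than this note shows. Statements on the series, on what has been measured and on what is new or still open speak of the compounds shown alone.

In an ADME assay on HEK-293T cells (Homo sapiens) for cytotoxicity, read by luminescence and CellTiter-Glo, with a stated time of 24 h (on this read-out higher numbers stand for lower toxicity in this test and lower numbers for higher toxicity in this test), compound 1 `CCCNC(=O)C1CCN(C(=O)c2cc3scnc3n2Cc2ccc(OC)cc2)CC1` gives 19100 nM, the lower of the two true numbers available. Compound 3 `CCCNC(=O)C1CC12CCN(C(=O)c1cc3sc(Br)nc3n1Cc1ccc(OC)cc1)CC2` gives 81300 nM, a higher number and a gap beyond the usual scatter. Compound 2 `CCCNC(=O)C1CCN(C(=O)c2cc3[nH]cnc3n2Cc2ccc(OC)cc2)CC1` gives > 100000 nM, which is a limit of the assay and not a number.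

The next compound to be tested, compound 4 `CCCNC(=O)C1CCN(C(=O)c2cc3sc(-c4ccccc4)nc3n2Cc2ccc(OC)cc2)CC1`, has phenyl in place of hydrogen on an aromatic carbon of the five-membered aromatic ring with 1 nitrogen and 1 sulfur (phenyl in place of hydrogen on an aromatic carbon). Among the measured compounds shown here, no measured pair differs in one place only, so the expectation rests on thin ground. Compound 3 also has a group other than hydrogen on that carbon and differs elsewhere as well, so its 81300 nM is only a loose hint towards a higher number in this assay. The expected change is small and may not exceed the scatter, with an estimated step of a 1.7-fold higher number from compound 1 to compound 4 (0.22 log units; within the scatter). For compound 4 the estimated value is 32000 nM, with an expected range of 10000 nM to 100000 nM.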

Compound 4, half-maximal cytotoxic concentration: 22900 nM
Beside the measured number, compound 4's estimate is 1.4-fold (0.15 log units) above it; low and high end bracket the measured number.
By their numbers in this assay, from the lowest: compounds 1 and 4 (each within the scatter of the next); then compound 3. At a limit, above all of these: compound 2.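

In this assay, phenyl in place of hydrogen on an aromatic carbon of the five-membered aromatic ring with 1 nitrogen and 1 sulfur gives a 1.2-fold higher number from compound 1 to compound 4 (0.08 log units; within the scatter). This is the first pair shown that differs in one place only, and it shows that this carbon can carry a phenyl, with its 6 heavy atoms, without a change that can be told from the scatter in this test. Nothing measured here gives a reason for this result.

The compounds shown leave open whether a smaller group on this same carbon, such as an amine or a methyl, would move the number beyond the scatter. Equally open, as far as these compounds go, is what a carboxylic acid or an amine on the added phenyl would do in this test.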